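The source may report more compounds than this note shows. Statements on the series, on what has been measured and on what is new or still open speak of the compounds shown alone.

Among the compounds with values here, compound 2, `CC/N=C(/NC#N)NCCCCn1nc(-c2ccccc2)ccc1=O`, gives the higher of the two numbers measured so far: in a functional assay on the whole organism with Rattus norvegicus as the target, at a dose of 100 mg/kg (on this read-out lower numbers stand for less inhibition and higher numbers for more inhibition at the one dose given (going by the name of the read-out)), compound 2 gives 58.8%. Within the data shown here, its nearest neighbour on that read-out is compound 1, `CC/N=C(\S)NCCCCCCn1nc(-c2ccccc2)ccc1=O`, which in this assay gives -5.6%; the one measured step, a number 64.4 percentage points higher from compound 1 to compound 2 (beyond the scatter), separates them.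

Compound 3, `C/N=C(/NC#N)NCCCCCn1nc(-c2ccccc2)ccc1=O`, has not yet been measured. It holds the same atoms as compound 2 but joined differently: a group of 8 heavy atoms (4 carbon, 4 nitrogen; no ring) in place of a group of 8 heavy atoms (4 carbon, 4 nitrogen; no ring), on a saturated chain carbon, four bonds along the chain from an aromatic nitrogen.

Among the measured compounds shown here, only one measured step exists, and it swapped a sulfur-bearing group for a nitrogen-rich one; the change from compound 2 to compound 3 keeps the same kind and count of atoms and only redistributes them, so that step bears on it only indirectly. For the measured compounds named here, with no measured pair of the same kind, the expected step in this assay from compound 2 to compound 3 is a number 6.8 percentage points lower from compound 2 to compound 3 (within the scatter), a change not expected to go beyond the scatter. Compound 3 is therefore estimated to give 52% in this assay, between 22% and 80%.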

Compound 3, a percentage reported as inhibition, in the whole organism at one dose (the size of the read-out at that dose, not a potency): 47.6%
Compound 3: the middle estimate sits 4.4 percentage points above what was measured; the range from low to high includes it.
By their numbers in this assay, from the lowest: compound 1; then compound 3; then compound 2.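

The shift in this assay shows that this position responds even when no atom is gained or lost: a number 11.2 percentage points lower from compound 2 to compound 3 (beyond the scatter), a modest change, and the group that leaves and the group that enters have the same counts of atoms, double and triple bonds, donors and acceptors. The large gain seen earlier is also no longer tied to compound 2 alone, since the second nitrile-bearing compound also stands well clear of the sulfur-bearing one, with a number 53.2 percentage points higher from compound 1 to compound 3 (beyond the scatter) as the step, so the two nitrile-bearing compounds differ far less from each other than either does from compound 1. No measurement offered here accounts for either step.

The compounds shown do not separate the contribution of the nitrile from that of the sulfur, or show how the result would change with a carboxylic acid, a simple amine or a longer chain at this saturated chain carbon. All three numbers also come from a single dose, so they leave open whether the order of compound 1, compound 3 and compound 2 would hold at other doses.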